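Chloro for nitro on the thiourea aryl ring

The compounds below may be only part of what the source reports. "The series", "measured", "known", "first", "only" and "open" are said of these compounds alone.

Measured so far:
compound 1, `COc1cc2c(cc1OC)C(=O)C(CC1CCN(C(=S)Nc3ccc(C)cc3)CC1)C2`, 4.58 in a physicochemical assay for lipophilicity; a lower number here means a more polar compound, a higher number a more lipophilic compound
compound 2, `COc1cc2c(cc1OC)C(=O)C(CC1CCN(C(=S)Nc3ccc([N+](=O)[O-])cc3)CC1)C2`, 4.58 in this assay

Compound 2 stands level with compound 1 in this assay at the digits shown, and the step of no change at the digits printed from compound 1 to compound 2 (within the scatter) lies within the scatter of repeated measurements. So far, then, swapping the group on this aromatic carbon has not moved the read-out.

Compound 3, `COc1cc2c(cc1OC)C(=O)C(CC1CCN(C(=S)Nc3ccc(Cl)cc3)CC1)C2`, has not yet been measured. It differs from compound 2 by chloro in place of nitro on an aromatic carbon.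

Among the measured compounds shown here, only one measured step bears on this change, the exchange of methyl for nitro from compound 1 to compound 2, and that step was flat. Chloro is a third group at the same place, and no measured pair shows what chloro does there. For the measured compounds named here, with the one comparable step showing no movement, the expectation is a small step or none beyond the scatter, leaning slightly upward because the flat step no change at the digits printed from compound 1 to compound 2 (within the scatter) gives no reason to expect a large drop.

Compound 3 is therefore expected to give about 4.7 in this assay, within a range of 4.3 to 5.1, an estimated step of a number 0.12 log units higher from compound 2 to compound 3 (within the scatter) from compound 2.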

Compound 3, partition coefficient: 5.11
Compound 3: middle estimate off by 0.41 log units, on the low side; measured number above the stated range.
By their numbers in this assay, from the lowest: compounds 1 and 2 (each within the scatter of the next); then compound 3.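

In this assay, among the compounds shown here, the group on this aromatic carbon, para to a large group, can move the read-out after all: chloro in place of nitro gives a number 0.53 log units higher from compound 2 to compound 3 (beyond the scatter) and is the first step at this place to lie beyond the scatter. Chloro in place of methyl gives a number 0.53 log units higher from compound 1 to compound 3 (beyond the scatter) of the same size, so compound 3 stands apart from compounds 1 and 2, which remain level with each other. The flat step between methyl and nitro therefore held for that pair of groups only and did not show that this place is indifferent to every group, though nothing available here explains why chloro stands apart from the other two.

With only three groups shown at this place, it remains open whether bromo, fluoro, methoxy or an amine would fall level with compound 3, level with compounds 1 and 2, or somewhere else. From the compounds shown here alone, it is also open whether chloro would give a similar step at another place on this aromatic ring, or whether the step would hold with a different group at the other end of the thiourea.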